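Swapping chloro for bromo on a weak cell inhibitor

A few compounds are considered here, and "the series" means these few. Any claim that something is new, unique, unknown or untested is made for them only; others in the source may bear on it.

Compound 1 `Clc1cc2cc(Br)[nH]c2cc1Cl`: 70000 nM
Compound 2 `OC[C@H]1O[C@@H](n2c(SCc3ccccc3)cc3cc(Cl)c(Cl)cc32)CC1O`: 60000 nM
Compound 3 `OC[C@H]1OC(n2c(Cl)cc3cc(Cl)c(Cl)cc32)[C@H](O)[C@@H]1O`: > 100000 nM

All three compounds were tested in a functional assay on KB cells (Homo sapiens) for inhibition; a lower number here means a stronger inhibitor, a higher number a weaker inhibitor. Compound 1 gives 70000 nM, and compound 2 gives 60000 nM, two values that lie within the usual scatter of each other. Compound 3 stands apart, since its result is a limit of this assay rather than a number: compound 3 reaches only > 100000 nM, which is the limit of > 100000 nM in this assay, at which 1 of the 3 values shown sits. So compound 3 sits at the weak end of what this assay can report, and its exact potency is unknown.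

Compound 4 `OC[C@H]1OC(n2c(Br)cc3cc(Cl)c(Cl)cc32)[C@H](O)[C@@H]1O` is the next compound to be measured. It differs from compound 3 in one place: bromo in place of chloro on an aromatic carbon. Among the compounds with values here, no measured pair in this set shows what such an exchange does, so the expected step is none beyond the scatter, as expressed by a number no higher from compound 3 to compound 4 (the limit leaves the size open). Compound 4 is therefore estimated at 100000 nM, with a range from 40000 nM to 300000 nM, and it may well again be reported only as a limit.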

Compound 4, half-maximal inhibitory concentration: > 100000 nM
Compound 4 was reported as a limit; the forecaster's own chance of this, stated with the estimate: 60%; the middle value sits exactly at the limit.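

Compound 3 and compound 4 both stop at the same limit in this assay, so no step can be read for bromo in place of chloro: the limit of > 100000 nM in this assay, at which 2 of the 4 values shown sit. The compounds shown leave open how strong either compound really is, and whether this exchange changes inhibition at all.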